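The source may report more compounds than this note shows. Statements on the series, on what has been measured and on what is new or still open speak of the compounds shown alone.

Measured so far in an ADME assay on RAW264.7 cells (Mus musculus) for cytotoxicity, read by MTT assay, with a stated time of 24 h, tested at 2.5 ug/mL; a higher number here means a weaker effect of the compound at the concentration tested, a lower number a stronger effect:

Compound 1, `COc1ccc(CCCc2ccc(OC)cc2OC)c(O)c1`, gives 97.7%.
Compound 2, `COc1ccc(CCCc2ccc(OC)cc2O)cc1`, gives 96.8%.
Compound 3, `COc1ccc(C(=O)CCc2ccc(OC)c(OC)c2)c(O)c1`, gives 89%.

All three compounds share a backbone of two six-membered aromatic rings joined by a three-atom bridge, each ring carrying methoxy groups and one ring carrying a free hydroxyl. Compound 3 differs from compound 2 in that its bridge holds a carbonyl and its methoxy groups sit differently; the difference between the two cores is not broken down here. Compound 3 is the lowest of the three numbers in this assay, but its gaps to compound 2 and to compound 1 both fall within the usual scatter, so the three values cannot be told apart.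

Within the data shown here, the one counted step runs from compound 2 to compound 1: methoxy in place of hydrogen on an aromatic carbon. This gave a number 0.9 percentage points higher from compound 2 to compound 1 (within the scatter).

Compound 4, `COc1ccc(C(=O)CCc2ccc(OC)c(OC)c2OC)c(O)c1`, is not yet measured. It is made from compound 3 by methoxy in place of hydrogen on an aromatic carbon. Among the measured compounds shown here, this is the same kind of change as the one from compound 2 to compound 1, though the place is not identical: in compound 4 the new group is also ortho to a methoxy group, whereas in compound 1 it is only ortho to a large group and meta to a methoxy group.

For compound 4 in this assay the step is expected to be a number 1 percentage points higher from compound 3 to compound 4 (within the scatter), resting on the earlier step, which was within the scatter, and on the measured value of compound 3, 89%. Compound 4 is therefore estimated at 90%, with a likely range from 80% to 99%.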

Compound 4, a percentage reported as activity, at one concentration (the size of the read-out at that concentration, not a potency): 94.4%
The estimate for compound 4 lay 4.4 percentage points below the measured number; the measured number falls inside the stated range.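

In this assay, methoxy in place of hydrogen on an aromatic carbon gave a number 5.4 percentage points higher from compound 3 to compound 4 (within the scatter). Set beside the earlier case of this change, the two steps cannot be told apart: the same change on two cores in this assay, a number 0.9 percentage points higher (within the scatter) from compound 2 to compound 1 and a number 5.4 percentage points higher (within the scatter) from compound 3 to compound 4, 4.5 percentage points apart, within the scatter of two such steps

So across these two cores, the change carries over in the limited sense that neither step stands out from the ordinary spread of repeated measurements, and the two steps do not disagree; it does not show that the change has no effect, or that it would behave the same way at another position or on another core, since only two pairs at a single concentration are available.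

The compounds shown carry only methoxy and hydroxyl groups on their aromatic rings, with a bridge that either holds a carbonyl or does not, so what an amine or a carboxylic acid on those rings would do in this assay remains open. Also open are the effect of a longer chain between the two rings and whether any of these compounds would separate from the others at a different concentration.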